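The compounds below may be only part of what the source reports. "The series", "measured", "known", "first", "only" and "open" are said of these compounds alone.

Three compounds in a small series of cinnamate-type esters and acids have been tested in a functional assay on ECV-304 cells (Homo sapiens) for cytotoxicity, read by MTT assay, with stated times of 24 h and 12 h; a lower number here means that less compound is needed, a higher number that more compound is needed for the effect. Compound 1 `CCOC(=O)/C=C/c1cc(OC)c(OCc2nc(C)c(C)nc2C)c(OC)c1` gives 2310000 nM in this assay. Compound 3 `COc1cc(/C=C/C(=O)O)cc(OC)c1OCc1nc(C)c(C)nc1C` carries a free acid where compound 1 carries an ester. In this assay compound 3 gives 3530000 nM. The change between them is hydrogen in place of ethyl on an oxygen next to a carbonyl group, and the step it made is a 1.5-fold higher number from compound 1 to compound 3 (0.18 log units; within the scatter), a movement too small to be read as a real difference. Compound 2 `CCOC(=O)/C=C/c1cc(Br)c(OCc2nc(C)c(C)nc2C)c(Br)c1`, with bromine atoms on its aromatic ring where compound 1 carries methoxy groups, stands apart. In this assay compound 2 gives 155000 nM, the lowest of the three numbers, and both compound 1 and compound 3 lie well beyond the scatter from it. The difference between the core of compound 2 and the core of compound 1 is not broken down here.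

Compound 4 `Cc1nc(C)c(COc2c(Br)cc(/C=C/C(=O)O)cc2Br)nc1C` is the acid belonging to compound 2 and has not yet been measured. The change from compound 2 to compound 4 is hydrogen in place of ethyl on an oxygen next to a carbonyl group, the same change as from compound 1 to compound 3, made at the same place. Resting on the outcome of that earlier step, which is a 1.5-fold higher number from compound 1 to compound 3 (0.18 log units; within the scatter), the expectation for compound 4 in this assay is a step of about a 1.5-fold higher number from compound 2 to compound 4 (0.17 log units; within the scatter). Compound 4 is therefore estimated at 230000 nM, with a plausible range from 100000 nM to 550000 nM.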

Compound 4, half-maximal effective concentration: 3280000 nM
Compound 4: middle estimate off by 14-fold (1.15 log units), on the low side; the measured number lies above the stated range.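

In this assay, hydrogen in place of ethyl on an oxygen next to a carbonyl group gives a 21-fold higher number from compound 2 to compound 4 (1.33 log units; beyond the scatter), so on this core the ester has the clearly lower number and the acid does not keep it. The same change therefore cannot be carried from one core to the other with a single expected size, and the earlier step on the core of compound 1 proved a poor guide to the step on the core of compound 2: the same change on two cores in this assay, a 1.5-fold higher number (0.18 log units; within the scatter) from compound 1 to compound 3 and a 21-fold higher number (1.33 log units; beyond the scatter) from compound 2 to compound 4, 14-fold (1.14 log units) apart, beyond the scatter of two such steps

This shows that the size of the step depends on the core in these two pairs, but it does not show which feature of the cores sets that size, and two pairs give no rule for any further core in the series.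

On these data alone, whether a methyl ester, a longer chain on the same oxygen or an amide in place of the ethyl ester would keep the low number of compound 2 remains open. As far as these compounds go, it is also open whether a core carrying chlorine or only a single bromine atom would follow the core of compound 2 or the core of compound 1 when the ester gives way to the carboxylic acid.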